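From methoxy to amino on a shared core

This account rests on a few compounds, and the source may have more. Where it says the series, first, only, none or still open, it means among the compounds named here.

Values in a functional assay on HCT-116 cells (Homo sapiens) for antiproliferative activity, read by MTT assay, with a stated time of 48 h (a higher number here means a weaker inhibitor, a lower number a stronger inhibitor), are
- compound 1 `CCCCCC(CCO)n1cnc2c(N)ncnc21` gives > 50000 nM as a limit of the assay, not a number
- compound 2 `CCCCCCCCCC(CCO)n1cnc2c(Cl)ncnc21` gives 890 nM
- compound 3 `CCCCCCCCCC(CCO)n1cnc2c(OC)ncnc21` gives 2530 nM

Of the two true numbers, compound 3 has the higher one, which makes it the weaker of that pair. Compound 4 `CCCCCCCCCC(CCO)n1cnc2c(N)ncnc21` has amino in place of methoxy on an aromatic carbon. For the measured compounds named here, only one measured step changes this same carbon, methoxy in place of chloro, and it was modest (a 2.8-fold higher number from compound 2 to compound 3 (0.45 log units; beyond the scatter)). Compound 1 also carries amino, on a shorter chain, and its result of > 50000 nM is a limit. A similar modest rise in the number is therefore expected in this assay (a 2.0-fold higher number from compound 3 to compound 4 (0.30 log units; within the scatter)). The estimate for compound 4 is 5000 nM (expected range 1500 nM to 20000 nM).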

Compound 4, half-maximal inhibitory concentration: 10500 nM
Estimate against measurement, compound 4: 2.1-fold (0.32 log units) below; the range from low to high includes it.
By their numbers in this assay, from the lowest: compound 2; then compound 3; then compound 4. At a limit, above all of these: compound 1.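

At this carbon of the shared core, amino extends the rise seen with methoxy in this assay, giving a 4.2-fold higher number from compound 3 to compound 4 (0.62 log units; beyond the scatter), and across the whole series of groups there is a 12-fold higher number from compound 2 to compound 4 (1.07 log units; beyond the scatter). With amino held in place, the side chain also matters, with an at least 4.7-fold lower number from compound 1 to compound 4 (0.67 log units; beyond the scatter). Compound 1 stands at a limit, not a number: the limit of > 50000 nM in this assay, at which 1 of the 4 values shown sits.

Going by these compounds, whether bromo or fluoro at this carbon would give a lower number than chloro remains open. So does whether a longer chain would lower the number further.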